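The compounds below may be only part of what the source reports. "The series", "measured", "known", "first", "only" and "open" are said of these compounds alone.

Measured in an assay on liver for binding affinity to Alpha-1D adrenergic receptor (Homo sapiens), using microsomes; on this read-out lower numbers stand for stronger inhibition and higher numbers for weaker inhibition:
Compound 1 `COC(=O)C1=C(C)NC(=O)N(C(=O)NCCCN2CCN(c3ccccc3OC)CC2)C1c1ccc(F)c(F)c1` gives 31 nM.
Compound 2 `CCOc1ccccc1N1CCN(CCCNC(=O)N2C(=O)NC(C)=C(C(=O)OC)C2c2ccc(F)c(F)c2)CC1` gives 14 nM.

Compound 2 stands lowest of the two numbers. Among the measured compounds shown here, the only measured step, a 2.2-fold lower number from compound 1 to compound 2 (0.35 log units; beyond the scatter), concerns the chain on the aromatic oxygen and is modest. Compound 3 `COC(=O)C1=C(C)NC(=O)N(C(=O)NCCCN2CCN(c3ccc(OC)cc3C)CC2)C1c1ccc(F)c(F)c1` differs from compound 2 by 4-methoxy-2-methylphenyl in place of 2-ethoxyphenyl on an amine nitrogen in a ring. For the measured compounds named here, no measured step bears on an exchange of this kind at the amine nitrogen in the ring, so the direction is open; compound 1, which carries a methoxy group, gives the higher of the two numbers. For compound 3 the expected step is a 2.1-fold higher number from compound 2 to compound 3 (0.33 log units; beyond the scatter). The estimate for compound 3 is 30 nM, range 8 nM to 120 nM.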

Compound 3, inhibition constant: 610 nM
The estimate for compound 3 lay 20-fold (1.31 log units) below the measured number; the measured number lies above the stated range.
By their numbers in this assay, from the lowest: compound 2; then compound 1; then compound 3.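

In this assay, the aryl group on the amine nitrogen in the ring proves far more sensitive than the chain on the aromatic oxygen: a 44-fold higher number from compound 2 to compound 3 (1.64 log units; beyond the scatter), and a 20-fold higher number from compound 1 to compound 3 (1.29 log units; beyond the scatter). The 2-ethoxyphenyl and 4-methoxy-2-methylphenyl groups have the same heavy-atom, donor and acceptor counts, so those counts do not account for this large step. Nothing available explains the rise.

As far as these compounds go, the change to 4-methoxy-2-methylphenyl alters two features at once, so their separate contributions remain open. Whether 2-methylphenyl or 4-methoxyphenyl alone carries the rise is also unresolved.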